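The source may report more compounds than this note shows. Statements on the series, on what has been measured and on what is new or still open speak of the compounds shown alone.

Three hydroxamic acids have been measured in a functional assay on NFF cells (Homo sapiens) for antiproliferative activity; on this read-out lower numbers stand for stronger inhibition and higher numbers for weaker inhibition. Compound 1 `O=C(Cc1c[nH]c2ccccc12)C[C@@H](Cc1ccccc1)C(=O)N[C@@H](CCCCCC(=O)NO)C(=O)NCc1ccccc1` gives 9800 nM, compound 2 `O=C(CCCCC[C@H](NC(=O)OCc1ccccc1)C(=O)Nc1ccc(-c2ccccc2)cc1)NO` gives 2200 nM, and compound 3 `O=C(CCCCC[C@H](NC(=O)c1ccc(Br)cc1)C(=O)Nc1ccc(-c2ccccc2)cc1)NO` gives 190 nM. Of these three numbers compound 2 stands second highest, between compound 1 and compound 3. For the measured compounds named here, the only measured step, a 12-fold lower number from compound 2 to compound 3 (1.06 log units; beyond the scatter), alters the group on a carbonyl carbon and leaves the 4-phenylphenyl on the amide-type nitrogen untouched. Compound 4 `O=C(CCCCC[C@H](NC(=O)OCc1ccccc1)C(=O)Nc1cccc2cccnc12)NO` changes that other place: quinolin-8-yl in place of 4-phenylphenyl on an amide-type nitrogen. Going by the values given here, no measured step bears on this position, so nothing in the data points to a direction, and a step no larger than the scatter is expected, a 1.1-fold higher number from compound 2 to compound 4 (0.06 log units; within the scatter). Compound 4 is accordingly estimated at 2500 nM, with a range from 700 nM to 9000 nM.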

Compound 4, half-maximal inhibitory concentration: 452 nM
Estimate against measurement, compound 4: 5.5-fold (0.74 log units) above; the whole stated range lies above it.
By their numbers in this assay, from the lowest: compound 3; then compound 4; then compound 2; then compound 1.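

In this assay the amide-type nitrogen proves to be a place that responds: a 4.9-fold lower number from compound 2 to compound 4 (0.69 log units; beyond the scatter) comes with quinolin-8-yl in place of 4-phenylphenyl. The group on the carbonyl carbon is therefore no longer the only place shown to move the read-out, and 4-phenylphenyl is not required on this nitrogen. Nothing measured here explains why the number falls.

The compounds shown do not tell whether the ring nitrogen of quinolin-8-yl matters, which a naphthalen-1-yl group at this place would test. They also leave open whether quinolin-8-yl and a 4-bromophenyl on the carbonyl carbon would add up.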